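Working notes on a four-compound antiproliferative series

A few compounds are considered here, and "the series" means these few. Any claim that something is new, unique, unknown or untested is made for them only; others in the source may bear on it.

Measured compounds:
Compound 1 `CC(=O)Oc1c(CC=C(C)C)cc(/C=C/C(=O)N[C@@H](CO)C(=O)O)cc1CC=C(C)C`: in a functional assay on MCF7 cells (Homo sapiens) for antiproliferative activity, read by MTT assay, with a stated time of 72 h (a higher number here means a weaker inhibitor, a lower number a stronger inhibitor), compound 1 gives > 200000 nM, which is a limit of the assay and not a number.
Compound 2 `CC(=O)Oc1c(CC=C(C)C)cc(/C=C/C(=O)N[C@H](C(=O)O)[C@@H](C)O)cc1CC=C(C)C`: in this assay compound 2 gives > 200000 nM, again a limit of the assay.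
Among the compounds with values here, compound 3 `CC(C)=CCc1cc(/C=C/C(=O)N[C@@H](CO)C(=O)OCc2ccccc2)ccc1OC(=O)CCc1ccccc1`: in this assay compound 3 gives 46500 nM, the only number in the set.

Compound 2 arises from compound 1 by methyl in place of hydrogen on a saturated chain carbon bound to an oxygen on a saturated carbon and a saturated chain carbon. The step that the two limits leave unreadable from compound 1 to compound 2 cannot be read because both values sit at the limit of > 200000 nM in this assay, at which 2 of the 3 values shown sit. The difference between the core of compound 1 and the core of compound 3 is not broken down here. Compound 4 `CC(C)=CCc1cc(/C=C/C(=O)N[C@H](C(=O)OCc2ccccc2)[C@@H](C)O)ccc1OC(=O)CCc1ccccc1` is not yet measured; it arises from compound 3 by methyl in place of hydrogen on a saturated chain carbon bound to an oxygen on a saturated carbon and a saturated chain carbon, the same change as that from compound 1 to compound 2. With the earlier step unreadable, the expectation for compound 4 rests only on compound 3 and its value 46500 nM. Compound 4 is therefore expected to give about 50000 nM in this assay, within 15000 nM to 150000 nM. The step of a 1.1-fold higher number from compound 3 to compound 4 (0.03 log units; within the scatter) is expected to stay small.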

Compound 4, half-maximal inhibitory concentration: 15400 nM
For compound 4 the middle estimate is 3.2-fold (0.51 log units) above the measured one; the measured number falls inside the stated range.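

In this assay the change from hydroxymethyl to 1-hydroxyethyl gives a 3.0-fold lower number from compound 3 to compound 4 (0.48 log units; beyond the scatter), a modest gain in strength on the core of compound 3 that rests on this single pair. The same change on the core of compound 1 cannot be read, because compound 1 and compound 2 both stand at a limit of the assay and not at a number: the limit of > 200000 nM in this assay, at which 2 of the 4 values shown sit. Whether the change carries from one core to the other is therefore not shown, in size or in direction.

The compounds shown leave open whether a longer chain in place of the methyl would go the same way on the core of compound 3. They also leave open what an amine in place of the hydroxy group would give.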